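This account rests on a few compounds, and the source may have more. Where it says the series, first, only, none or still open, it means among the compounds named here.

Measured so far:
- compound 1 `C=C1CCC[C@H]2[C@](C)(CC[C@]3(C)CC[C@H]([C@@H](C)C(=O)O)OO3)[C@@H](C)CC[C@]12C`: 1930 nM
- compound 2 `C=C1CCCC(C)(C)C1CC[C@@]1(C)CC[C@H]([C@@H](C)C(=O)O)OO1`: > 12500 nM

Within the data shown here, in a functional assay on A498 cells (Homo sapiens) for inhibition (a lower number here means a stronger inhibitor of growth, a higher number a weaker inhibitor of growth), compound 1 gives 1930 nM and is the only compound of the pair with a number rather than a limit. For compound 2 the assay returns only a limit, > 12500 nM. The second entry is therefore (the limit of > 12500 nM in this assay, at which 1 of the 2 values shown sits), and nothing can be said about a step between compound 1 and compound 2 beyond the fact that one has a value and the other a limit.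

The next compound, compound 3 `C=C1CCC[C@H]2[C@](C)(CC[C@]3(C)CC[C@@H]([C@@H](C)C(=O)O)OO3)[C@@H](C)CC[C@]12C`, differs from compound 1 as follows: the two compounds have the same atoms and bonds and differ only in configuration as drawn: 1 of 7 stereo elements differ; a stereocentre at a saturated ring carbon is drawn R in compound 1 and S in compound 3. Both keep the shared core, the endoperoxide ring and the propanoic acid side chain; only the configuration at one saturated ring carbon is inverted. Among the measured compounds shown here, no measured pair in this set shows what inverting a single stereocentre does here, so the expected step carries wide uncertainty. The working expectation is that compound 3 stays near compound 1 in this assay, with a tilt toward weaker growth inhibition rather than stronger. The step from compound 1 to compound 3 is expected to be a 1.8-fold higher number from compound 1 to compound 3 (0.26 log units; within the scatter). Compound 3 is accordingly estimated at 3500 nM, with a range from 900 nM to 14000 nM.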

Compound 3, concentration for 50% growth inhibition: 1590 nM
The estimate for compound 3 lay 2.2-fold (0.34 log units) above the measured number; low and high end bracket the measured number.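

Working notes: in this assay, inverting the stereocentre at a saturated ring carbon from R to S comes with a 1.2-fold lower number from compound 1 to compound 3 (0.08 log units; within the scatter). Among these compounds, this is the first pair that can be read as a single change, and at this position the assay does not separate the two configurations. The reading concerns configuration alone, with no group leaving or entering and the endoperoxide ring and propanoic acid side chain kept in both compounds: the fact that compounds 1 and 3 differ only in the configuration as drawn

Among the compounds shown here, for compound 2 the entry > 12500 nM is a limit of the assay, and no step involving it can be read. Still open, from the compounds shown here alone, is whether the other stereocentres of the shared core can be inverted with as little consequence, and whether the result for this position holds when the carboxylic acid of the propanoic acid side chain gives way to a methyl ester, a primary amide or a longer chain.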